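One Methyl Removed, Once Measured and Once Still Open

This account rests on a few compounds, and the source may have more. Where it says the series, first, only, none or still open, it means among the compounds named here.

Of the compounds shown here, three have been measured in a functional assay on NCI-H727 cells (Homo sapiens) for cytotoxicity, with a stated time of 48 h; a lower number here means a stronger inhibitor, a higher number a weaker inhibitor. Compound 1, `COc1cc(OC)c(C(=O)/C=C/c2ccccc2OC)c(OC)c1`, gives 4000 nM in this assay. Compound 2, `COc1cccc(/C=C/C(=O)c2c(OC)cc(OC)cc2OC)c1`, differs from compound 1 in one way: 3-methoxyphenyl in place of 2-methoxyphenyl on a double-bonded chain carbon bound to a double-bonded chain carbon. In this assay compound 2 gives 8200 nM, and the step is a 2.1-fold higher number from compound 1 to compound 2 (0.31 log units; beyond the scatter). Compound 3, `COc1cc(O)c(C(=O)/C=C/c2ccccc2OC)c(OC)c1`, differs from compound 1 in that (hydrogen in place of methyl on an oxygen on an aromatic ring). In this assay compound 3 gives 11000 nM, which makes the step of a 2.8-fold higher number from compound 1 to compound 3 (0.44 log units; beyond the scatter). The values of compound 2 and compound 3 lie within the usual scatter of each other, so nothing separates those two.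

Compound 4, `COc1cccc(/C=C/C(=O)c2c(O)cc(OC)cc2OC)c1`, has not yet been measured. It differs from compound 2 in that (hydrogen in place of methyl on an oxygen on an aromatic ring). This is the same change as the one from compound 1 to compound 3, at the same place, and it has been seen only that once among these compounds. The expected step for this assay is a 2.8-fold higher number from compound 2 to compound 4 (0.45 log units; beyond the scatter). Among the measured compounds shown here, that expectation rests on the single earlier step of a 2.8-fold higher number from compound 1 to compound 3 (0.44 log units; beyond the scatter). For the measured compounds named here, it is only one example of the change, and the range around the estimate is kept wide. For compound 4 in this assay the estimated value is 23000 nM, expected to fall between 10000 nM and 50000 nM.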

Compound 4, half-maximal inhibitory concentration: 14800 nM
The estimate for compound 4 lay 1.6-fold (0.19 log units) above the measured number, and the stated range covers the measured number.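

In this assay, exchanging methoxy for hydroxy on the second core gives a 1.8-fold higher number from compound 2 to compound 4 (0.26 log units; within the scatter), so on this core the step alone cannot be told apart from the ordinary differences between repeated measurements. Set beside the first example of the same change, on the core of compound 1, the two steps do not differ by more than such measurements allow: the same change on two cores in this assay, a 2.8-fold higher number (0.44 log units; beyond the scatter) from compound 1 to compound 3 and a 1.8-fold higher number (0.26 log units; within the scatter) from compound 2 to compound 4, 1.5-fold (0.18 log units) apart, within the scatter of two such steps. This fits the idea that the change carries from one core to the other in this assay, but it rests on just two pairs, only one of which is beyond the scatter, so it establishes neither a fixed size for the step nor a rule for any further core.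

The compounds shown carry only methoxy or hydroxy at this place, so they leave open what a longer chain on the oxygen, such as ethoxy, or an amine in place of the hydroxy would do to the number. They also say nothing about why the change behaves as it does, or about whether the same step would appear in a cell line other than the one used here.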